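Chloro in Place of Methyl: Expected Potency of Compound 4

The compounds below may be only part of what the source reports. "The series", "measured", "known", "first", "only" and "open" are said of these compounds alone.

Going by the values given here, compound 3 `Cc1cc(Cl)c2c(c1)/C(=C/C(N)=O)CC2` is the one compound of the three measured that carries only a limit in a functional assay on the whole organism with Rattus norvegicus as the target, with a stated time of 3 h; a higher number here means that more compound is needed for the effect, a lower number that less compound is needed. In this assay compound 3 gives > 25 mg/kg, which is a limit of the assay rather than a measured number (the limit of > 25 mg/kg in this assay, at which 1 of the 3 values shown sits). Measured numbers belong to compound 1 `CNC(=O)/C=C1\CCc2c(Cl)cc(F)cc21`, which gives 8 mg/kg in this assay, and to compound 2 `NC(=O)/C=C1\CCc2c(Cl)cc(F)cc21`, which gives 11 mg/kg in this assay. The step of a 1.4-fold higher number from compound 1 to compound 2 (0.14 log units; within the scatter) lies within the scatter, whereas the step of an at least 2.2-fold higher number from compound 2 to compound 3 (0.35 log units; beyond the scatter) is at least modest. Compound 4 `NC(=O)/C=C1\CCc2c(Cl)cc(Cl)cc21` differs from compound 3 by chloro in place of methyl on an aromatic carbon. Among the compounds with values here, no measured step shows chloro entering at that carbon; the only step touching the same position is an at least 2.2-fold higher number from compound 2 to compound 3 (0.35 log units; beyond the scatter), where a halogen leaves and methyl enters, and it raised the number. Returning a halogen to that position therefore suggests a lower number for compound 4 in this assay, of uncertain size. Compound 4 is estimated at 15 mg/kg, between 6 mg/kg and 40 mg/kg. That estimate for compound 4 amounts to the expected step of an at least 1.6-fold lower number from compound 3 to compound 4 (0.22 log units; that floor lies within the scatter), bringing compound 4 back toward the measured range rather than leaving it at a limit.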

Compound 4, dose for half-maximal effect: 25 mg/kg
For compound 4 the middle estimate is 1.7-fold (0.22 log units) below the measured one; low and high end bracket the measured number.
By their numbers in this assay, from the lowest: compounds 1 and 2 (each within the scatter of the next); then compound 4.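

In this assay chloro in place of fluoro on this aromatic carbon gives a 2.3-fold higher number from compound 2 to compound 4 (0.36 log units; beyond the scatter) as a modest step, so a halogen at this position does not by itself return the number to that of compound 2. Going by these compounds alone, until now, the only evidence at this carbon was the change from fluoro to methyl, which ended at a limit; the change between two halogens now has a size that can be read. Compound 3 stands at a limit of the assay, so a number no higher from compound 3 to compound 4 (the limit leaves the size open) is all that can be said of that step, and its size cannot be read: the limit of > 25 mg/kg in this assay, at which 1 of the 4 values shown sits.

The compounds shown leave open how a nitrile, a methoxy group or an amine on this carbon would read. They also leave open whether methyl on the amide nitrogen of compound 4 would shift its number, or whether that step would stay within the scatter, as it does between compound 1 and compound 2.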